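A few compounds are considered here, and "the series" means these few. Any claim that something is new, unique, unknown or untested is made for them only; others in the source may bear on it.

Compound 1 `CC(C)(C)CNC(=O)C[C@H](NC(=O)CCc1ccccc1)C(=O)N[C@@H](CCc1ccccc1)C(=O)NCc1ccccc1` serves as the reference point of this set. In an assay on HEK293 cells for inhibition of nuclear factor NF-kappa-B complex (Homo sapiens), read by a luciferase reporter, with stated times of 1 h and 3 h (a higher number here means a weaker inhibitor, a lower number a stronger inhibitor), compound 1 gives 12 nM. Compound 3 `CC(C)(C)CNC(=O)C[C@H](NC(=O)CCc1ccccc1)C(=O)N[C@@H](CCc1ccccc1)C(=O)NCc1ccccc1Cl` carries one change relative to compound 1, chloro in place of hydrogen on an aromatic carbon, and in this assay compound 3 gives 18 nM. The resulting step is a 1.5-fold higher number from compound 1 to compound 3 (0.18 log units; within the scatter), so the two compounds cannot be told apart by this measurement.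

Compound 2 `CC(C)(C)CNC(=O)C[C@H](NC(=O)c1ccc(OCc2ccccc2)cc1)C(=O)N[C@@H](CCc1ccccc1)C(=O)NCc1ccccc1` rests on a different core; the difference between the two cores is not broken down here. In this assay compound 2 gives 22 nM, and its value lies within the scatter of both compound 1 and compound 3, so no order among the three can be claimed.

Compound 4 `CC(C)(C)CNC(=O)C[C@H](NC(=O)c1ccc(OCc2ccccc2)cc1)C(=O)N[C@@H](CCc1ccccc1)C(=O)NCc1ccccc1Cl` is not yet measured. It stands to compound 2 as compound 3 stands to compound 1: the same change, chloro in place of hydrogen on an aromatic carbon, made at the same kind of place, ortho to a large group. Going by the values given here, the one measured instance of this change, from compound 1 to compound 3, stayed within the scatter, and that is the only evidence available. On that basis the step is expected to be a 1.4-fold higher number from compound 2 to compound 4 (0.13 log units; within the scatter), that is, again within the scatter. Compound 4 is therefore estimated to give 30 nM in this assay, with a likely range from 12 nM to 75 nM.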

Compound 4, half-maximal inhibitory concentration: 39 nM
Estimate against measurement, compound 4: 1.3-fold (0.11 log units) below; low and high end bracket the measured number.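

In this assay, the second instance of chloro in place of hydrogen on an aromatic carbon, on the benzyl group of the core of compound 2, gives a 1.8-fold higher number from compound 2 to compound 4 (0.25 log units; within the scatter), so this pair cannot be told apart by this measurement. Set beside the first instance, on the core of compound 1, the change reads the same on both cores as far as this measurement can resolve: the same change on two cores in this assay, a 1.5-fold higher number (0.18 log units; within the scatter) from compound 1 to compound 3 and a 1.8-fold higher number (0.25 log units; within the scatter) from compound 2 to compound 4, 1.2-fold (0.07 log units) apart, within the scatter of two such steps This shows that, in these two cases, going from benzyl to 2-chlorobenzyl left the number within the scatter whichever core carried it, but with neither step beyond the scatter it does not show that the chloro has any effect at all, and two cores in one assay make no rule for the rest of the series.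

The compounds shown leave open whether the same reading would hold with a fluoro, a methyl or a methoxy group in place of the chloro, or with an amine or a carboxylic acid on that benzyl group. They also leave open how the change would read on any core other than these two.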